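This account rests on a few compounds, and the source may have more. Where it says the series, first, only, none or still open, it means among the compounds named here.

In an ADME assay on isolated protein for inhibition of protein deacetylase HDAC6 (Homo sapiens), read by fluorescence, with stated times of 3 h and 60 min (on this read-out higher numbers stand for weaker inhibition and lower numbers for stronger inhibition), compound 1 `N[C@@H](CCCCCC(=O)c1ccon1)c1ncc(-c2ccccc2F)[nH]1` reaches only the assay's limit of > 45000 nM, a boundary rather than a measured number. Compound 2 `CN1CC(C(=O)N[C@@H](CCCCCC(=O)c2ncco2)c2ncc(-c3ccc(F)cc3)[nH]2)C1` likewise stops at the limit of > 45000 nM. Compound 3 `Cc1coc(C(=O)CCCCC[C@H](NC(=O)C2CCN(C)CC2)c2ncc(-c3ccc(F)cc3)[nH]2)n1` stops at the limit of > 15000 nM. Two of the three results sit at the limit of > 45000 nM in this assay, at which 2 of the 3 values shown sit, and one at the limit of > 15000 nM in this assay, at which 1 of the 3 values shown sits, so compound 1 stands among compounds for which no inhibition could be quantified. Compound 4 `N[C@@H](CCCCCC(=O)c1cocn1)c1ncc(-c2ccccc2F)[nH]1` is not yet measured; it differs from compound 1 by 1,3-oxazol-4-yl in place of 1,2-oxazol-3-yl on a carbonyl carbon, the two having the same atoms joined differently. Within the data shown here, no measured pair shows a step of this kind, and since every value shown is a limit, no change beyond the scatter is expected. Compound 4 is therefore estimated at 45000 nM, between 10000 nM and 100000 nM, meaning an expected step of a number no higher from compound 1 to compound 4 (the limit leaves the size open).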

Compound 4, half-maximal inhibitory concentration: > 45000 nM
Compound 4 gave a limit, no number; the forecaster's own chance of this, stated with the estimate: 90%; the middle value sits exactly at the limit.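

Among these compounds, compound 1 and compound 4 both end at a limit of the assay rather than a number, so no step between them can be read. The compounds shown leave open whether either oxazole isomer inhibits this enzyme at any concentration.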